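Moving the Methyl Around the Phenyl Ring

The source may hold more compounds than are shown below. What is called first, only, known or untested is meant among the compounds shown, and "the series" means these compounds.

Of the compounds shown here, three built on one shared core have been tested for how strongly they slow the growth of a breast-cancer cell line. In a functional assay on T47D cells (Homo sapiens) for antiproliferative activity, read by MTT assay, with a stated time of 48 h (a lower number here means a stronger inhibitor, a higher number a weaker inhibitor), compound 1 `Cc1cccc(NC(=O)Nc2nnc(Sc3ncnc4scc(-c5ccncc5)c34)s2)c1` gives 27200 nM, the lowest of the two plain numbers known here. Compound 2 `Cc1ccc(NC(=O)Nc2nnc(Sc3ncnc4scc(-c5ccncc5)c34)s2)cc1Cl` gives 34800 nM in this assay, and the step of a 1.3-fold higher number from compound 1 to compound 2 (0.11 log units; within the scatter) stays within the scatter, so the two cannot be ranked. Compound 3 `COc1ccc(NC(=O)Nc2nnc(Sc3ncnc4scc(-c5ccncc5)c34)s2)cc1` reaches only a limit of the method in this assay, > 100000 nM, and no number is known for it. the limit of > 100000 nM in this assay, at which 1 of the 3 values shown sits. Even so, that limit fixes a floor for the steps of an at least 3.6-fold higher number from compound 1 to compound 3 (0.56 log units; beyond the scatter) and an at least 2.8-fold higher number from compound 2 to compound 3 (0.45 log units; beyond the scatter).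

Compound 4 `Cc1ccc(NC(=O)Nc2nnc(Sc3ncnc4scc(-c5ccncc5)c34)s2)cc1` awaits measurement. It differs from compound 1 by 4-methylphenyl in place of 3-methylphenyl on an amide-type nitrogen. Going by the values given here, two measured steps bear on this change. Adding a chlorine to a ring that already carries a methyl changed little, as the step from compound 1 to compound 2 shows. Placing a methoxy on the ring where the methyl of compound 4 now sits, as in compound 3, weakened inhibition beyond the scatter. Between these, compound 4 is expected to be a somewhat weaker inhibitor than compound 1, by a 1.7-fold higher number from compound 1 to compound 4 (0.22 log units; within the scatter), though the gap might fall within the scatter. The estimate for compound 4 in this assay is 45000 nM, between 18000 nM and 110000 nM.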

Compound 4, half-maximal inhibitory concentration: 17800 nM
Compound 4: middle estimate off by 2.5-fold (0.40 log units), on the high side; the measured number lies below the stated range.
By their numbers in this assay, from the lowest: compounds 4, 1 and 2 (each within the scatter of the next). At a limit, above all of these: compound 3.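

Moving the methyl, with 3-methylphenyl giving way to 4-methylphenyl on the amide-type nitrogen, does not separate the two compounds in this assay: the change gives a 1.5-fold lower number from compound 1 to compound 4 (0.18 log units; within the scatter), so the two positions of the methyl cannot be told apart here. Taking the chlorine away is just as unrewarding to read, since hydrogen in place of chloro on an aromatic carbon gives a 2.0-fold lower number from compound 2 to compound 4 (0.29 log units; within the scatter), which leaves compounds 1, 2 and 4 as one group with no order among them. The change that does show is a swap of the group itself rather than a move, as methyl in place of methoxy on an aromatic carbon gives an at least 5.6-fold lower number from compound 3 to compound 4 (0.74 log units; beyond the scatter), a floor and not an exact size, for compound 3 stands at a limit of the assay and has no number: the limit of > 100000 nM in this assay, at which 1 of the 4 values shown sits.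

The compounds shown leave open how a group such as ethyl, a fluorine or a hydroxyl would behave on this ring, and whether any of them would fall with the methyl of compound 4 or with the methoxy of compound 3. They also leave open what an amine, a carboxylic acid or a longer chain at this place would do in this assay.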